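Swapping ethyl for propargyl beside a trimethoxyphenyl amine

The source may hold more compounds than are shown below. What is called first, only, known or untested is meant among the compounds shown, and "the series" means these compounds.

Compound 3 `CCN(Cc1nc2cc(C(F)(F)F)ccc2nc1-c1ccccc1)c1cc(OC)c(OC)c(OC)c1` carries a 3,4,5-trimethoxyphenyl group on its amine nitrogen, and in an assay on isolated protein for inhibition of Dihydrofolate reductase (Homo sapiens), read by spectrophotometry (on this read-out lower numbers stand for stronger inhibition and higher numbers for weaker inhibition), compound 3 gives 6000 nM. Within the data shown here, two compounds share its core and vary only that aromatic group: in this assay compound 1 `CCN(Cc1nc2cc(C(F)(F)F)ccc2nc1-c1ccccc1)c1ccc(OC)cc1` gives 7000 nM and compound 2 `CCN(Cc1nc2cc(C(F)(F)F)ccc2nc1-c1ccccc1)c1ccc(F)c(F)c1` gives 5000 nM. The steps of a 1.4-fold lower number from compound 1 to compound 2 (0.15 log units; within the scatter), a 1.2-fold lower number from compound 1 to compound 3 (0.07 log units; within the scatter) and a 1.2-fold higher number from compound 2 to compound 3 (0.08 log units; within the scatter) all stay within the scatter, so the three numbers cannot be ranked. Compound 4 `C#CCN(Cc1nc2cc(C(F)(F)F)ccc2nc1-c1ccccc1)c1cc(OC)c(OC)c(OC)c1` differs from compound 3 by ethynyl in place of methyl on a saturated chain carbon bound to a nitrogen on an aromatic ring. Among the measured compounds shown here, no measured step touches this chain; the steps seen only exchange the aromatic group on the amine nitrogen, and each stayed within the scatter. With nothing pointing either way, the expected step is no change at the digits printed from compound 3 to compound 4 (within the scatter), no change beyond the scatter. Compound 4 is therefore estimated at 6000 nM, with a range from 2500 nM to 14000 nM.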

Compound 4, inhibition constant: 4000 nM
Beside the measured number, compound 4's estimate is 1.5-fold (0.18 log units) above it, within the range that was stated.
By their numbers in this assay, from the lowest: compounds 4, 2, 3 and 1 (each within the scatter of the next).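

The earlier compounds shown here all keep ethyl and vary only the aromatic group, whereas this pair changes the chain on the amine nitrogen. In this assay the change from ethyl to propargyl gives a 1.5-fold lower number from compound 3 to compound 4 (0.18 log units; within the scatter) with the 3,4,5-trimethoxyphenyl group held constant, so this chain change, like the aromatic exchanges, leaves the reading within the scatter. No supporting measurement bears on this result.

Other groups on this nitrogen, such as a longer chain, an amine or a carboxylic acid, remain open. So does whether propargyl gives the same result alongside the 3,4-difluorophenyl group.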